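The source may report more compounds than this note shows. Statements on the series, on what has been measured and on what is new or still open speak of the compounds shown alone.

Measured in a functional assay for inhibition; on this read-out higher numbers stand for weaker inhibition and lower numbers for stronger inhibition:
Compound 1 `CC(C)(C)c1cc(-c2cc(=O)c3ccc(OCCO)cc3o2)cc(C(C)(C)C)c1O`: 3000 nM
Compound 2 `CC(C)(C)c1cc(-c2cc(=O)c3ccc(O)cc3o2)cc(C(C)(C)C)c1O`: 1000 nM

Of these two compounds, compound 2 has the lower number, 1000 nM, and is therefore the stronger inhibitor in this assay. Compound 3 `CCCCCOC(=O)COc1ccc2c(=O)cc(-c3cc(C(C)(C)C)c(O)c(C(C)(C)C)c3)oc2c1` keeps the core of compound 2 but has (pentyloxycarbonyl)methyl in place of hydrogen on an oxygen on an aromatic ring.

Within the data shown here, one measured step bears on this change: a 3.0-fold lower number from compound 1 to compound 2 (0.48 log units; beyond the scatter), where hydrogen replaces 2-hydroxyethyl at the same kind of oxygen. Read in reverse, this modest step shows a substituent on that oxygen going with a higher number. Among the measured compounds shown here, it is a single step, however, and no measured compound carries (pentyloxycarbonyl)methyl, so the guidance is limited. A step of similar size toward weaker inhibition is therefore expected, though a larger or smaller one would not be surprising. The expected change is a 3.0-fold higher number from compound 2 to compound 3 (0.48 log units; beyond the scatter). Compound 3 is estimated at 3000 nM, with an expected range of 800 nM to 10000 nM.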

Compound 3, half-maximal inhibitory concentration: 5000 nM
Compound 3: middle estimate off by 1.7-fold (0.22 log units), on the low side; the measured number falls inside the stated range.
By their numbers in this assay, from the lowest: compound 2; then compounds 1 and 3 (each within the scatter of the next).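

In this assay, placing (pentyloxycarbonyl)methyl on the oxygen on an aromatic ring gives a 5.0-fold higher number from compound 2 to compound 3 (0.70 log units; beyond the scatter), so a second, different substituent at this oxygen also goes with a higher number than the free hydroxy. Replacing hydroxymethyl with pentyloxycarbonyl on the saturated chain carbon bound to that oxygen gives a 1.7-fold higher number from compound 1 to compound 3 (0.22 log units; within the scatter), a step within the scatter, so the read-out does not separate the two substituents despite their different chain ends. Nothing available accounts for the higher numbers of the substituted compounds or for the lack of separation between them.

From the compounds shown here alone, it remains open whether any group on this oxygen could match or lower the number of the free hydroxy, and a simple methyl ether, the free carboxylic acid corresponding to the ester, or a chain ending in an amine would each test this in a different way. The role of the pentyl part also remains open, since the compounds shown do not include a methyl or ethyl ester of the same acid.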